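The source may hold more compounds than are shown below. What is called first, only, known or untested is meant among the compounds shown, and "the series" means these compounds.

Measured so far:
compound 1 `CCCCCCCCc1ccc(OCC(=O)Cn2nnc(C(=O)O)n2)cc1`: 52%
compound 2 `CCCCCCCCc1ccc(OCC(=O)Cn2nnnc2SC)cc1`: 21%

Both were tested in an ADME assay on S9 fraction from liver (Rattus norvegicus) for metabolic stability, read by LC-MS, using NADPH, with a stated time of 30 min; on this read-out lower numbers stand for a less stable compound and higher numbers for a more stable compound. For the measured compounds named here, compound 2 stands at the bottom of these two numbers; its only neighbour is compound 1, and the step of a number 31 percentage points lower from compound 1 to compound 2 (beyond the scatter) is large and clearly beyond the usual scatter. Compound 3 `CCCCCCCCc1ccc(OCC(=O)Cn2nnnc2-c2ccccn2)cc1` has not been measured yet. It differs from compound 2 in a single place: pyridin-2-yl in place of methylsulfanyl on an aromatic carbon. Going by the values given here, the one measured step is the only guide, and it shows that changing the group on the five-membered aromatic ring with 4 nitrogen can move the percentage remaining a long way. Neither group in that step is pyridin-2-yl, however, so its direction gives no firm pointer. Compound 3 is therefore expected to show a step of a number 11 percentage points higher from compound 2 to compound 3 (beyond the scatter), a modest rise with wide uncertainty. The estimate for compound 3 is 32%, between 12% and 58%.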

Compound 3, percent of the compound remaining: < 5%
Compound 3 ended at the assay's limit; the forecaster's own chance of this, stated with the estimate: 3%; at least 27 percentage points between middle value and limit.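

In this assay, this step changes only the group on the aromatic carbon of the five-membered aromatic ring with 4 nitrogen, and it gives a number at least 16 percentage points lower from compound 2 to compound 3 (beyond the scatter). The earlier compounds shown here did not show that an aromatic ring at this place, larger than methylsulfanyl, could take the percentage remaining down to the floor of the read-out. For compound 3, < 5% is a limit of the assay and not a number, so the step has a known minimum but no known full size: the limit of < 5% in this assay, at which 1 of the 3 values shown sits.

As far as these compounds go, whether a plain phenyl ring, without the ring nitrogen of pyridin-2-yl, or a small amine at this same carbon would behave like either group stays open. The compounds shown also do not tell which part of the molecule is lost during the incubation.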